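The compounds below may be only part of what the source reports. "The series", "measured", "known", "first", "only" and "open" are said of these compounds alone.

Two compounds of the series carry numbers in a functional assay on HUVEC cells (Homo sapiens) for antiproliferative activity, read by MTT assay, with a stated time of 48 h (on this read-out lower numbers stand for stronger inhibition and higher numbers for weaker inhibition), so far. Compound 1 `Cc1cccc(NC(=O)Nc2nnc(Sc3ncnc4scc(-c5ccncc5)c34)s2)c1` gives 12200 nM in this assay. Among the compounds with values here, compound 2 `O=C(Nc1ccc(F)cc1)Nc1nnc(Sc2ncnc3scc(-c4ccncc4)c23)s1` gives 28300 nM in this assay; the one measured step, a 2.3-fold higher number from compound 1 to compound 2 (0.37 log units; beyond the scatter), is modest. Compound 2 thus stands with the highest of the two numbers, and compound 1 is its nearest neighbour.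

Compound 3 `O=C(Nc1ccc(Cl)cc1)Nc1nnc(Sc2ncnc3scc(-c4ccncc4)c23)s1` differs from compound 2 by chloro in place of fluoro on an aromatic carbon. Within the data shown here, no measured step exchanges only this halogen. Among the measured compounds shown here, the one step that bears on the region at all, a 2.3-fold higher number from compound 1 to compound 2 (0.37 log units; beyond the scatter), replaces the whole substituted phenyl and still shifts the number only modestly, so a single halogen exchange on the phenyl ring is not expected to carry the number beyond the scatter. The step from compound 2 to compound 3 is expected to be a 1.4-fold lower number from compound 2 to compound 3 (0.15 log units; within the scatter). Compound 3 is therefore estimated at 20000 nM in this assay, with a range of 8000 nM to 50000 nM.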

Compound 3, half-maximal inhibitory concentration: 11600 nM
Estimate against measurement, compound 3: 1.7-fold (0.24 log units) above; measured number inside the range.
By their numbers in this assay, from the lowest: compounds 3 and 1 (each within the scatter of the next); then compound 2.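

In this assay, the halogen on the aromatic carbon para to a large group is not a neutral exchange: chloro in place of fluoro gives a modest change (a 2.4-fold lower number from compound 2 to compound 3 (0.39 log units; beyond the scatter)), beyond the scatter. Within the data shown here, the comparison of the two aryl groups on the amide-type nitrogen also shifts, since 4-chlorophenyl and 3-methylphenyl are not told apart (a 1.1-fold lower number from compound 1 to compound 3 (0.02 log units; within the scatter)), which leaves 4-fluorophenyl in compound 2 as the one group of the three with a separate, higher number. No supporting data are available to explain why chloro and fluoro differ here.

From the compounds shown here alone, whether bromo, methoxy or nitrile at the same place would fall with chloro or with fluoro stays open, as does the number for an unsubstituted phenyl. Also open, going by these compounds, is whether chloro elsewhere on the ring would keep this level.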